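Thiolanyl Amine Replacing Methyl on the Core of Compound 1

The compounds below may be only part of what the source reports. "The series", "measured", "known", "first", "only" and "open" are said of these compounds alone.

Measured compounds:
compound 1, `CNc1nc2ccccc2c(=O)o1`: > 62500 nM
compound 2, `Cc1cccc(C)c1Nc1nc2ccccc2c(=O)o1`: > 62500 nM

In an assay on isolated protein for inhibition of complement C1r subcomponent (Homo sapiens) (on this read-out lower numbers stand for stronger inhibition and higher numbers for weaker inhibition), compound 1 gives > 62500 nM, which is a limit of the assay rather than a number. Compound 2 likewise gives only a limit in this assay, > 62500 nM. Both measured values thus sit at the limit of > 62500 nM in this assay, at which 2 of the 2 values shown sit, so compound 1 cannot be placed anywhere except at that limit, alongside compound 2; neither compound shows measurable inhibition within the range of this assay.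

Compound 3, `O=c1oc(NC2CCSC2)nc2ccccc12`, differs from compound 1 by thiolan-3-yl in place of methyl on a nitrogen on an aromatic ring. Going by the values given here, no step between measured compounds is available, so the size of this change cannot be read from any measured pair, and whether a larger saturated ring on that nitrogen shifts the read-out is open.

Given that compound 1 and compound 2 both rest at the limit, the step of an at least 1.2-fold lower number from compound 1 to compound 3 (0.09 log units; that floor lies within the scatter) is expected to be modest at best, in the direction of stronger inhibition only if the new group gains anything at all. Compound 3 is therefore estimated at 50000 nM, within 10000 nM to 200000 nM, with a further limit the likelier outcome.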

Compound 3, half-maximal inhibitory concentration: > 62500 nM
Compound 3: no number, only a limit; the forecaster's own chance of this, stated with the estimate: 70%; middle value at least 1.2-fold (0.09 log units) away from the limit.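

No step from compound 1 to compound 3 can be read in this assay, because both compounds rest at a limit rather than a number: the limit of > 62500 nM in this assay, at which 3 of the 3 values shown sit.

The compounds shown leave open whether any group on that nitrogen, thiolan-3-yl included, can bring the shared core to a measurable value in this assay.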